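The source may hold more compounds than are shown below. What is called first, only, known or untested is meant among the compounds shown, and "the series" means these compounds.

In an in vitro ADME assay on microsomes from liver (Homo sapiens) for metabolic stability, in the presence of a further agent that is not named here (a lower number here means slower removal, a higher number faster removal of the compound), compound 1 `CC(C)(CO)CNC(=O)c1cc2cc(C#N)ccc2n1Cc1cccc(OC(F)(F)F)c1` gives 20 mL.min-1.g-1 and stands level at the digits shown with compound 3 `CCOc1ccc(OC(F)(F)F)cc1Cn1c(C(=O)NCC(C)(C)CO)cc2cc(C#N)ccc21` at 20 mL.min-1.g-1 in the same read-out, while compound 2 `COc1ccc(OC(F)(F)F)cc1Cn1c(C(=O)NCC(C)(C)CO)cc2cc(C#N)ccc21` gives 31 mL.min-1.g-1 and all three lie within the scatter of one another. Compound 4 `CC(C)(O)CCNC(=O)c1cc2cc(C#N)ccc2n1Cc1cccc(OC(F)(F)F)c1` has the same atoms as compound 1 joined differently (2-hydroxy-2-methylpropyl in place of 1-(hydroxymethyl)-1-methylethyl on a saturated chain carbon bound to an amide-type nitrogen) so that (2-(hydroxymethyl)-2-methylpropyl)carbamoyl becomes (3-hydroxy-3-methylbutyl)carbamoyl. The measured steps, namely a 1.6-fold higher number from compound 1 to compound 2 (0.19 log units; within the scatter) together with no change at the digits printed from compound 1 to compound 3 (within the scatter) and a 1.6-fold lower number from compound 2 to compound 3 (0.19 log units; within the scatter) all stay within the scatter, and they concern a substituent on an aromatic carbon, not this amide chain. Among the compounds with values here, no measured step touches the change at hand, so the expectation rests on compound 1 at 20 mL.min-1.g-1 with no shift beyond the scatter foreseen. In this assay the expected outcome is no change at the digits printed from compound 1 to compound 4 (within the scatter) as an estimate, with neither direction favoured. For compound 4 the estimated value is 20 mL.min-1.g-1 with an expected range from 10 mL.min-1.g-1 to 40 mL.min-1.g-1 in this measurement.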

Compound 4, intrinsic clearance in microsomes: < 6 mL.min-1.g-1
Compound 4 was reported as a limit (the forecaster's own chance of this, stated with the estimate: 2%); middle value at least 3.3-fold (0.52 log units) away from the limit.
By their numbers in this assay, from the lowest: compounds 1, 3 and 2 (each within the scatter of the next). At a limit, below all of these: compound 4.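

Replacing 1-(hydroxymethyl)-1-methylethyl with 2-hydroxy-2-methylpropyl on a saturated chain carbon bound to an amide-type nitrogen gives an at least 3.3-fold lower number from compound 1 to compound 4 (0.52 log units; beyond the scatter) in this assay. The earlier steps, all concerning a substituent on an aromatic carbon, stayed within the scatter, so this amide chain is the first place in the series shown where the read-out moves beyond it, and it does so with the same atoms joined differently. The result for compound 4 is a limit and not a number: the limit of < 6 mL.min-1.g-1 in this assay, at which 1 of the 4 values shown sits.

From the compounds shown here alone, whether 3-hydroxy-3-methylbutyl gives a similar step alongside the methoxy of compound 2 or the ethoxy of compound 3 remains open. So does what an amine, a carboxylic acid or a longer chain would give on this amide nitrogen.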